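Swapping the aryl group on the hydrazone of an anilinoquinazoline urea

This account rests on a few compounds, and the source may have more. Where it says the series, first, only, none or still open, it means among the compounds named here.

Compound 3 `COc1cc2ncnc(Nc3ccc(F)c(Cl)c3)c2cc1NC(=O)N/N=C/c1ccc(F)cc1` is a close relative of compound 1 `O=C(N/N=C/c1ccc(F)cc1)Nc1cc2c(Nc3ccc(F)c(Cl)c3)ncnc2cc1O[C@H]1CCOC1` and compound 2 `O=C(N/N=C/c1ccc(O)c(Br)c1)Nc1cc2c(Nc3ccc(F)c(Cl)c3)ncnc2cc1O[C@H]1CCOC1`, all sharing the same core and differing only at the ends. In a functional assay on A549 cells (Homo sapiens) for cytotoxicity, read by MTT assay, with a stated time of 72 h (a lower number here means a stronger inhibitor, a higher number a weaker inhibitor), compound 3 gives 26600 nM, which is the second highest of the three numbers measured. Compound 1 gives 35100 nM, and a 1.3-fold lower number from compound 1 to compound 3 (0.12 log units; within the scatter), so these two cannot be told apart. Compound 2 gives 4310 nM, and an 8.1-fold lower number from compound 1 to compound 2 (0.91 log units; beyond the scatter).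

Compound 4 `CCN(CC)c1ccc(/C=N/NC(=O)Nc2cc3c(Nc4ccc(F)c(Cl)c4)ncnc3cc2OC)c(O)c1` is built from compound 3 by one change: 4-(diethylamino)-2-hydroxyphenyl in place of 4-fluorophenyl on a carbon with a double bond to nitrogen. Among the measured compounds shown here, the only measured step that bears on this is the one from compound 1 to compound 2, where a group carrying a hydroxyl on the aromatic ring likewise replaced 4-fluorophenyl on the carbon with a double bond to nitrogen. For the measured compounds named here, that step was modest but beyond the scatter, so a step of similar size and in the same direction is expected here, with the caveat that the entering group differs from the one in compound 2, so the size is uncertain. The expected step is a 5.3-fold lower number from compound 3 to compound 4 (0.73 log units; beyond the scatter), because compound 2 showed an 8.1-fold lower number from compound 1 to compound 2 (0.91 log units; beyond the scatter). Compound 4 is therefore estimated at 5000 nM, with a range from 1500 nM to 16000 nM.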

Compound 4, half-maximal inhibitory concentration: 27300 nM
Beside the measured number, compound 4's estimate is 5.5-fold (0.74 log units) below it; measured number outside the range, above it.
By their numbers in this assay, from the lowest: compound 2; then compounds 3, 4 and 1 (each within the scatter of the next).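

In this assay the change from 4-fluorophenyl to 4-(diethylamino)-2-hydroxyphenyl on the carbon with a double bond to nitrogen gives a 1.0-fold higher number from compound 3 to compound 4 (0.01 log units; within the scatter) and so leaves the number within the scatter, despite the larger entering group with its added hydrogen-bond donor and acceptors. A hydroxyl on the aromatic ring at this place is therefore not enough on its own to give a lower number, since compound 4 carries one and shows no step beyond the scatter, unlike an 8.1-fold lower number from compound 1 to compound 2 (0.91 log units; beyond the scatter) with 3-bromo-4-hydroxyphenyl on the compound with oxolan-3-yl on the oxygen. The data shown offer no measured explanation for this difference between the two aryl groups.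

As far as these compounds go, it remains open whether 3-bromo-4-hydroxyphenyl would give a similarly lower number with methyl on the oxygen, which would separate the effect of the aryl group from that of the oxygen substituent. The compounds shown also leave open how a simpler group such as 4-hydroxyphenyl or 3-bromophenyl would read at this place, which would show whether the hydroxyl, the bromine or both go with the lower number.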